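Swapping a chlorinated aryl amide for an oxane amide

This account rests on a few compounds, and the source may have more. Where it says the series, first, only, none or still open, it means among the compounds named here.

Compound 1 `CC(C)(C)c1cc(NC(=O)[C@@H]2CCCCN2C2CCOCC2)no1` gives 74 ug/mL in a physicochemical assay for solubility, read by HPLC, at pH 6.8; a lower number here means a less soluble compound, a higher number a more soluble compound.
Compound 2 `CC(C)(C)c1cc(NC(=O)[C@@H]2CCCCN2C(=O)c2ccc(Cl)cc2)no1` gives < 0.1 ug/mL in this assay; this value is a limit of the assay, not a number.

Compound 2 therefore sits at the floor of what this measurement can report, (the limit of < 0.1 ug/mL in this assay, at which 1 of the 2 values shown sits). Within the data shown here, the only measured step, an at least 740-fold lower number from compound 1 to compound 2 (2.86 log units; beyond the scatter), shows how far the number fell when the ring amine of compound 1 was turned into an amide carrying a chlorinated aryl group. Compound 3 `CC(C)(C)c1cc(NC(=O)[C@@H]2CCCCN2C(=O)C2CCOCC2)no1` keeps the amide but changes the group attached to it: oxan-4-yl in place of 4-chlorophenyl on a carbonyl carbon. This undoes part of that step, restoring the oxan-4-yl ring of compound 1 while keeping the carbonyl of compound 2. The measured step cannot be split into its two parts, and compound 2 sits at a limit, so the distance that could be recovered is not known. Still, a rise in this assay is expected, estimated as an at least 50-fold higher number from compound 2 to compound 3 (1.69 log units; beyond the scatter). Compound 3 is therefore expected to give about 5 ug/mL, within a range of 0.5 ug/mL to 50 ug/mL.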

Compound 3, solubility: 48 ug/mL
Compound 3: middle estimate off by 9.6-fold (0.98 log units), on the low side; low and high end bracket the measured number.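

At this position, on a carbonyl carbon whose other neighbour is the amide-type nitrogen in a ring, the attached group decides the reading in this assay: with the amide kept, oxan-4-yl in place of 4-chlorophenyl gives an at least 480-fold higher number from compound 2 to compound 3 (2.68 log units; beyond the scatter). The carbonyl alone makes no difference that this measurement can separate, as (oxan-4-yl)carbonyl in place of oxan-4-yl on the amine nitrogen in the ring gives a 1.5-fold lower number from compound 1 to compound 3 (0.19 log units; within the scatter), so among these three compounds the large fall goes with 4-chlorophenyl and not with the amide. The reading for compound 2 is a limit of the assay and not a number, so the rise to compound 3 is known only as a minimum: the limit of < 0.1 ug/mL in this assay, at which 1 of the 3 values shown sits.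

The compounds shown leave open whether the fall belongs to the chlorine or to the aromatic ring itself, a question that a plain phenyl on the same carbonyl would address. They also leave open how far the reading would move with other groups on this carbonyl, such as a short alkyl chain, a piperidine amine or a benzoic acid.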